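Extending the Side Chain on a Second Core

A few compounds are considered here, and "the series" means these few. Any claim that something is new, unique, unknown or untested is made for them only; others in the source may bear on it.

Compound 1 `CCCC/C=C\CCCCCCCCCC1(O)CC(=O)c2c(O)cc(OCOC)cc2O1` and compound 2 `CCCCC/C=C\C/C=C\CCCCCCCC1(O)CC(=O)c2c(O)cc(OCOC)cc2O1` share one core and differ in a single place on the side chain: deca-1,4-dien-1-yl in place of oct-3-en-1-yl on a saturated chain carbon, seven bonds along the chain from a saturated ring carbon. In a functional assay on MDA-MB-231 cells (Homo sapiens) for antiproliferative activity, read by MTT assay (on this read-out lower numbers stand for stronger inhibition and higher numbers for weaker inhibition), compound 1 gives 42800 nM. Compound 2 gives 16100 nM, so this change made a 2.7-fold lower number from compound 1 to compound 2 (0.42 log units; beyond the scatter). Compound 3 `CCCC/C=C\CCCCCCCCCc1cc(=O)c2c(O)cc(OCOC)c(C)c2o1` carries the shorter chain on a different core; how the two cores differ is not broken down here. For compound 3 this assay reports only > 87000 nM, a limit rather than a number: the limit of > 87000 nM in this assay, at which 1 of the 3 values shown sits. Compound 4 `CCCCC/C=C\C/C=C\CCCCCCCc1cc(=O)c2c(O)cc(OCOC)c(C)c2o1` has not yet been measured. It differs from compound 3 by the same kind of change: deca-1,4-dien-1-yl in place of oct-3-en-1-yl on a saturated chain carbon, seven bonds along the chain from an aromatic carbon; here the chain sits seven bonds along the chain from an aromatic carbon, whereas in compound 1 and compound 2 it sits seven bonds along the chain from a saturated ring carbon. For compound 4 a step of roughly an at least 1.4-fold lower number from compound 3 to compound 4 (0.16 log units; that floor lies within the scatter) is expected in this assay, resting on the earlier 2.7-fold lower number from compound 1 to compound 2 (0.42 log units; beyond the scatter), though the starting point being a limit leaves the size uncertain. Compound 4 is therefore estimated at 60000 nM, between 25000 nM and 150000 nM.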

Compound 4, half-maximal inhibitory concentration: 16100 nM
Compound 4: middle estimate off by 3.7-fold (0.57 log units), on the high side; measured number outside the range, below it.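

Replacing oct-3-en-1-yl with deca-1,4-dien-1-yl on the second core gives an at least 5.4-fold lower number from compound 3 to compound 4 (0.73 log units; beyond the scatter) in this assay. Within the data shown here, the change therefore moves the number in the same direction on both cores, though this rests on only two pairs of compounds: the same change on two cores in this assay, a 2.7-fold lower number (0.42 log units; beyond the scatter) from compound 1 to compound 2 and an at least 5.4-fold lower number (0.73 log units; beyond the scatter) from compound 3 to compound 4; the limit leaves it open whether they differ. Compound 3 gives a limit and not a number, so the data do not show whether the change has a larger effect on one core than on the other: the limit of > 87000 nM in this assay, at which 1 of the 4 values shown sits.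

The two chains shown differ in both length and number of double bonds, so it remains open which of these features matters, and a fully saturated chain or a still longer chain could help separate them. From the compounds shown here alone, it is also open whether the same direction would hold for a chain ending in a carboxylic acid or an amine, or for the same change on a third core.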